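The source may hold more compounds than are shown below. What is called first, only, known or untested is meant among the compounds shown, and "the series" means these compounds.

Measured so far:
- compound 1 `O=C(Nc1ccc(Nc2ncnc3c2OCCN3)cc1)Nc1ccc(C(F)(F)F)cc1` gives 276 nM in an assay on isolated protein for inhibition of proto-oncogene tyrosine-protein kinase receptor Ret variant V804M (Homo sapiens), read by 33P incorporation, with stated times of 15 min and 40 min; a lower number here means a stronger inhibitor, a higher number a weaker inhibitor
- compound 2 `Cc1ccc(F)c(NC(=O)Nc2ccc(Nc3ncnc4c3OCCN4)cc2)c1` gives 5110 nM in this assay
- compound 3 `Cc1cc(C)cc(NC(=O)Nc2ccc(Nc3ncnc4c3OCCN4)cc2)c1` gives 971 nM in this assay

All three share one core and differ only in the aryl group that sits on an amide-type nitrogen of the urea. On these numbers compound 3 stands second highest of three. Its nearest neighbour is compound 1, the step being a 3.5-fold higher number from compound 1 to compound 3 (0.55 log units; beyond the scatter), and its furthest is compound 2, with a 5.3-fold lower number from compound 2 to compound 3 (0.72 log units; beyond the scatter). Both steps are modest, while a 19-fold higher number from compound 1 to compound 2 (1.27 log units; beyond the scatter) shows that a change at this same amide-type nitrogen can also cost a great deal.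

Compound 4 `O=C(Nc1ccc(Nc2ncnc3c2OCCN3)cc1)Nc1cccc2ccccc12` has not yet been measured. It differs from compound 3 in one place: naphthalen-1-yl in place of 3,5-dimethylphenyl on an amide-type nitrogen. The measured steps all concern swaps of the aryl group on this nitrogen, so they are the ones that bear on the new compound, yet none of them introduces a second fused aromatic ring, so they bound the likely size of the effect only loosely. The three aryl groups seen so far span modest to large differences, and a naphthalen-1-yl group is a larger departure from the 3,5-dimethylphenyl than a single substituent swap.

In this assay a weakening is expected for compound 4, of the size a 2.1-fold higher number from compound 3 to compound 4 (0.31 log units; beyond the scatter). The estimate for compound 4 is 2000 nM, with a range from 500 nM to 8000 nM.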

Compound 4, half-maximal inhibitory concentration: > 10000 nM
Compound 4: a limit, no number; the forecaster's own chance of this, stated with the estimate: 5%; middle value at least 5.0-fold (0.69 log units) from the limit.
By their numbers in this assay, from the lowest: compound 1; then compound 3; then compound 2. At a limit, above all of these: compound 4.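

In this assay compound 4 gives a limit of the assay and not a number: the limit of > 10000 nM in this assay, at which 1 of the 4 values shown sits.

Until now every aryl group on this amide-type nitrogen had a single ring, and all three compounds gave a number; with naphthalen-1-yl in place of 3,5-dimethylphenyl, the two-ring group brings an at least 10-fold higher number from compound 3 to compound 4 (1.01 log units; beyond the scatter), and the gap to the best compound shown is wider still, with an at least 36-fold higher number from compound 1 to compound 4 (1.55 log units; beyond the scatter). So a swap at this nitrogen that adds only a little to the group's size can cost as much as the largest change seen before, or more. Going by these compounds alone, only the comparison with the weakest of the earlier compounds stays loose, with an at least 1.9-fold higher number from compound 2 to compound 4 (0.29 log units; that floor lies within the scatter), so compound 4 cannot be firmly set apart from compound 2.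

The compounds shown cannot tell whether the loss comes from the second fused ring itself or from the way it is joined to the urea nitrogen, and the limit hides how large the loss really is. Also open, on these data alone, is how this nitrogen would respond to a plain phenyl, or to a phenyl carrying a methoxy group, an amine or a carboxylic acid.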